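The source may hold more compounds than are shown below. What is called first, only, known or untested is meant among the compounds shown, and "the series" means these compounds.

Of the compounds shown here, two in this study have been tested in a functional assay on BXPC-3 cells (Homo sapiens) for inhibition, read by MTT assay, with a stated time of 7 days (on this read-out higher numbers stand for weaker inhibition and lower numbers for stronger inhibition), so far, and they differ from each other in more than one place, so no single step between them can be isolated. Compound 1, with structure `CCN(CC)S(=O)(=O)c1ccc(S(=O)(=O)N2CCC[C@@H](C(=O)N3CCC(O)CC3)C2)cc1`, gives 4710 nM in this assay; that is the highest of the two numbers, meaning the weaker inhibition. Within the data shown here, compound 2, with structure `CCN(CC)C(=O)c1ccc(S(=O)(=O)N2CCC[C@@H](C(=O)N3CCC(F)(F)CC3)C2)cc1`, gives 240 nM in this assay, a value well beyond the scatter from that of compound 1, but since the two structures differ in two places at once, the two values show only that the pair together makes a large difference, not which part of the change is responsible.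

Compound 3, with structure `CCN(CC)S(=O)(=O)c1ccc(S(=O)(=O)N2CCC[C@@H](C(=O)N3CCC(C(F)(F)F)CC3)C2)cc1`, has not yet been measured. It differs from compound 1 in one place: trifluoromethyl in place of hydroxy on a saturated ring carbon. Among the measured compounds shown here, no measured pair shows this change alone, so the expected size of the step rests only on the gap between compound 1 and compound 2. In this assay, the step from compound 1 to compound 3 is expected to be a 3.1-fold lower number from compound 1 to compound 3 (0.50 log units; beyond the scatter), toward stronger inhibition, though with real uncertainty. Compound 3 is accordingly estimated to give 1500 nM, within a range of 400 nM to 5000 nM.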

Compound 3, half-maximal inhibitory concentration: 370 nM
Beside the measured number, compound 3's estimate is 4.1-fold (0.61 log units) above it; the whole stated range lies above it.
By their numbers in this assay, from the lowest: compounds 2 and 3 (each within the scatter of the next); then compound 1.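

In this assay, among these compounds, the change from 4-hydroxypiperidin-1-yl to 4-(trifluoromethyl)piperidin-1-yl gives a 13-fold lower number from compound 1 to compound 3 (1.10 log units; beyond the scatter), and this is the first time a change at this saturated ring carbon can be read on its own. The step is large, so inhibition in this assay clearly depends on what this carbon carries, and the hydroxy of compound 1 is not needed for activity in this pair, since compound 3 has no hydrogen-bond donor or acceptor in that group and is the stronger inhibitor of the two. Nothing measured here bears on why the number falls.

One swap removes a small group and adds a larger one at the same time, so this pair cannot tell whether losing the hydroxy or gaining the trifluoromethyl matters more, and a plain hydrogen, a methyl, a methoxy or an amine on that ring carbon would help to separate the two. Among the compounds shown here, also open is whether a step of this size would hold on a different core, such as the one in compound 2, which carries a carbonyl in place of one sulfonyl.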